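This account rests on a few compounds, and the source may have more. Where it says the series, first, only, none or still open, it means among the compounds named here.

Compound 1 `NC(=O)c1c(NC(=O)c2cccc([N+](=O)[O-])c2)sc2c1CCN(Cc1ccc(Cl)cc1Cl)C2`, compound 2 `NC(=O)c1c(NC(=O)c2ccccc2Br)sc2c1CCN(C(=S)Nc1ccccc1Cl)C2` and compound 3 `COc1ccccc1C(=O)Nc1sc2c(c1C(N)=O)CCN(C(=S)Nc1ccccc1Cl)C2` share one core and differ at two places. In a functional assay on HeLa cells (Homo sapiens) for antiproliferative activity, with a stated time of 24 h (on this read-out lower numbers stand for stronger inhibition and higher numbers for weaker inhibition), compound 1 gives 33000 nM. In this assay compound 2 gives 46900 nM. For compound 3 this assay reports only a limit, > 50000 nM, which is where compound 3 stands. Going by the values given here, the one measured step that bears on the next change runs an at least 1.0-fold higher number from compound 2 to compound 3 (0.02 log units; that floor lies within the scatter); it rests on (the limit of > 50000 nM in this assay, at which 1 of the 3 values shown sits), so its true size is not known beyond that floor. Compound 4 `NC(=O)c1c(NC(=O)c2cccc([N+](=O)[O-])c2)sc2c1CCN(C(=S)Nc1ccccc1Cl)C2` differs from compound 3 by 3-nitrophenyl in place of 2-methoxyphenyl on a carbonyl carbon. Compound 1 carries the same 3-nitrophenyl group on a core with a different substituent and sits at 33000 nM, so the nitro group alone does not carry a compound far from the others here. The step from compound 3 to compound 4 in this assay is therefore expected to be small or within the scatter, an at least 1.2-fold lower number from compound 3 to compound 4 (0.09 log units; that floor lies within the scatter). For compound 4 in this assay a value of 40000 nM is expected, within 15000 nM to 100000 nM.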

Compound 4, half-maximal inhibitory concentration: 40300 nM
For compound 4 the middle estimate is 1.0-fold (0.00 log units) below the measured one; low and high end bracket the measured number.
By their numbers in this assay, from the lowest: compounds 1, 4 and 2 (each within the scatter of the next). At a limit, above all of these: compound 3.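

In this assay, the group on the carbonyl carbon can now be compared between two measured numbers: the step from 2-bromophenyl to 3-nitrophenyl is a 1.2-fold lower number from compound 2 to compound 4 (0.07 log units; within the scatter). The other place is now also seen as a single step, with the group on the amine nitrogen in a ring exchanged while the 3-nitrophenyl stays, and this gives a 1.2-fold higher number from compound 1 to compound 4 (0.09 log units; within the scatter). Against the 2-methoxyphenyl group there is only a floor, an at least 1.2-fold lower number from compound 3 to compound 4 (0.09 log units; that floor lies within the scatter), and its true size stays unknown: the limit of > 50000 nM in this assay, at which 1 of the 4 values shown sits.

No step shown at either place goes beyond the scatter, so it remains open whether any change there can move the number that far. On these data alone, it also remains open what an amine or a carboxylic acid on the phenyl ring in place of the nitro group would give.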